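Methoxy Step Carried From One Core to Another

The compounds below may be only part of what the source reports. "The series", "measured", "known", "first", "only" and "open" are said of these compounds alone.

Measured so far:
compound 1, `Cc1cc(C)cc(NC(=O)Cn2ccc(=O)c3ccccc32)c1`, 3.54
compound 2, `Cc1cc(C)cc(NC(=O)COc2ccnc3ccccc23)c1`, 5.03
compound 3, `COc1ccc2nccc(OCC(=O)Nc3cc(C)cc(C)c3)c2c1`, 5.3

Of the compounds shown here, three have been measured in a physicochemical assay for lipophilicity, at pH 7.4; a lower number here means a more polar compound, a higher number a more lipophilic compound. Compound 1 gives 3.54, the lowest of the three. Compound 2 gives 5.03. Compound 3 gives 5.3. Compound 1 and compound 2 share the same atoms joined differently, and the difference between the two cores is not broken down here. Compound 3 differs from compound 2 by methoxy in place of hydrogen on an aromatic carbon, and that change made a step of a number 0.27 log units higher from compound 2 to compound 3 (within the scatter).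

Compound 4, `COc1ccc2c(c1)c(=O)ccn2CC(=O)Nc1cc(C)cc(C)c1`, has not yet been measured in this assay. It differs from compound 1 by methoxy in place of hydrogen on an aromatic carbon, the same change placed the same way. The step from compound 1 to compound 4 is expected to be a number 0.26 log units higher from compound 1 to compound 4 (within the scatter) because a number 0.27 log units higher from compound 2 to compound 3 (within the scatter). Compound 4 is therefore estimated at 3.8, expected to fall between 3.4 and 4.3.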

Compound 4, distribution coefficient: 3.72
The estimate for compound 4 lay 0.08 log units above the measured number; the range from low to high includes it.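

In this assay, methoxy in place of hydrogen on an aromatic carbon made a step of a number 0.18 log units higher from compound 1 to compound 4 (within the scatter) on one core and a step of a number 0.27 log units higher from compound 2 to compound 3 (within the scatter) on the other. Both steps lie within the scatter, so in these two pairs the change carried across without a step that can be told from repeat measurement on either core. This does not show that methoxy shifts the number by any real amount, or that the same would hold on any further core, and nothing available bears on why the two steps look as they do.

The compounds shown leave open whether an amine or a carboxylic acid on the same aromatic carbon would step beyond the scatter. They also leave open how a longer chain, such as ethoxy, would behave there on either core.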